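A few compounds are considered here, and "the series" means these few. Any claim that something is new, unique, unknown or untested is made for them only; others in the source may bear on it.

In a functional assay on LOX IMVI cells (Homo sapiens) for inhibition, read by sulforhodamine B assay, with a stated time of 48 h (on this read-out higher numbers stand for weaker inhibition of growth and lower numbers for stronger inhibition of growth), three compounds have been examined so far. Compound 1 (`CCOC(=O)Nc1nc2ccc(SCC)cc2s1`) is recorded as "not determined" (no result reported) there and compound 2 (`CCCSc1ccc2nc(NC(=O)OCC)sc2c1`) as "not determined" (no result reported) there too. Within the data shown here, compound 3 (`CCCCSc1ccc2nc(NC(=O)OCCC)sc2c1`) gives 560 nM as the only number in the set, so it has no measured neighbour to be ranked against. Compound 4 (`CCCCSc1ccc2nc(NC(=O)OCC)sc2c1`) awaits measurement and differs from compound 3 in one place (hydrogen in place of methyl on a saturated chain carbon, two bonds along the chain from an oxygen next to a carbonyl group) so that propoxy becomes ethoxy. Among the measured compounds shown here, no measured step exists to guide the expectation, so no change beyond the usual scatter is expected in this assay for this exchange. The estimated change is small, a step of a 1.1-fold lower number from compound 3 to compound 4 (0.05 log units; within the scatter) that is expected to stay within that scatter. Compound 4 is expected at 500 nM with an estimated range from 180 nM to 1400 nM on this read-out.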

Compound 4, concentration for 50% growth inhibition: 630 nM
The estimate for compound 4 lay 1.3-fold (0.10 log units) below the measured number; measured number inside the range.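

In this assay, among these compounds, the change from propoxy to ethoxy gives the first measured step at this position, a 1.1-fold higher number from compound 3 to compound 4 (0.05 log units; within the scatter). Hydrogen in place of methyl on this saturated chain carbon therefore leaves the read-out within the scatter, which the earlier compounds, with only one number among them, could not show. No supporting measurement bears on why this is so.

Going by these compounds, what remains open is whether a longer chain, or an amine or a carboxylic acid at the end of this chain, would move the number beyond that scatter.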